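Swapping fluoro for chloro on the sulfonate aryl group

A few compounds are considered here, and "the series" means these few. Any claim that something is new, unique, unknown or untested is made for them only; others in the source may bear on it.

Measured in a functional assay on M21 cells (Homo sapiens) for antiproliferative activity, read by sulforhodamine B assay, with a stated time of 48 h; on this read-out higher numbers stand for weaker inhibition and lower numbers for stronger inhibition:
- Compound 1 `CCCN1CCN(c2ccc(S(=O)(=O)Oc3ccccc3OC)cc2)C1=O`: > 100000 nM (a limit of the assay)
- Compound 2 `CCCN1CCN(c2ccc(S(=O)(=O)Oc3cccc(F)c3)cc2)C1=O`: 12000 nM

Within the data shown here, compound 2 is the only compound here with a plain number. The entry for compound 1 is a limit. Compound 3 `CCCN1CCN(c2ccc(S(=O)(=O)Oc3cccc(Cl)c3)cc2)C1=O` differs from compound 2 in one place: chloro in place of fluoro on an aromatic carbon, meta to a large group. Among the measured compounds shown here, only one measured step bears on this, and only indirectly: an at least 8.3-fold lower number from compound 1 to compound 2 (0.92 log units; beyond the scatter). That step exchanged a whole group, 3-fluorophenyl in place of 2-methoxyphenyl, and its size is open-ended. It gives no direct measure of chloro against fluoro, so no step beyond the scatter is expected in this assay, and neither direction is favoured. The expected change is a 1.2-fold lower number from compound 2 to compound 3 (0.08 log units; within the scatter). Compound 3 is estimated at 10000 nM, with an expected range from 3500 nM to 30000 nM.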

Compound 3, half-maximal inhibitory concentration: 8600 nM
For compound 3 the middle estimate is 1.2-fold (0.07 log units) above the measured one, and the stated range covers the measured number.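

In this assay, chloro in place of fluoro on an aromatic carbon, meta to a large group, gives a 1.4-fold lower number from compound 2 to compound 3 (0.14 log units; within the scatter), so at this position the two halogens cannot be told apart. Exchanging the whole aryl group of the sulfonate gives an at least 11-fold lower number from compound 1 to compound 3 (1.06 log units; beyond the scatter), which lies beyond the scatter, as the step to the 3-fluorophenyl compound did, so the same gain now appears with a second halogen. The size of this step stays open-ended because it starts from a limit of the assay: the limit of > 100000 nM in this assay, at which 1 of the 3 values shown sits.

The compounds shown leave open whether a plain phenyl, or a methoxy group on the same carbon, would give a similar number, and so whether the halogen itself matters. They also leave open how a nitrile or a trifluoromethyl group would read at this position.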